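Swapping fluoro for chloro in compound 3

The compounds below may be only part of what the source reports. "The series", "measured", "known", "first", "only" and "open" are said of these compounds alone.

Measured so far in a toxicity assay on MT4 cells (Homo sapiens) for cytotoxicity, read by MTT assay; on this read-out lower numbers stand for higher toxicity in this test and higher numbers for lower toxicity in this test
- Compound 1 `COc1cc(Oc2cc(N)nc(Nc3ccc(C#N)cc3)n2)ccc1-c1ccc(C#N)cc1` gives 12900 nM
- Compound 2 `Cc1cc(Oc2cc(N)nc(Nc3ccc(C#N)cc3)n2)ccc1-c1ccc(C#N)cc1` gives 34300 nM
- Compound 3 `Cc1cc(-c2ccc(F)cc2)cc(C)c1Oc1cc(N)nc(Nc2ccc(C#N)cc2)n1` gives 23100 nM

Compound 3 at 23100 nM lies within the usual scatter of both compound 1 and compound 2, so it cannot be ranked against either. Compound 4 `Cc1cc(-c2ccc(Cl)cc2)cc(C)c1Oc1cc(N)nc(Nc2ccc(C#N)cc2)n1` has chloro in place of fluoro on an aromatic carbon, turning 4-fluorophenyl into 4-chlorophenyl chloro in place of fluoro on an aromatic carbon with nothing else altered. Among the measured compounds shown here, the only measured step is a 2.7-fold higher number from compound 1 to compound 2 (0.42 log units; beyond the scatter) and it is a modest one. It involves methyl in place of methoxy, a different swap, so it offers only a rough sense of scale. No step beyond the scatter is expected in this assay here. The estimated change is a 1.1-fold lower number from compound 3 to compound 4 (0.04 log units; within the scatter) and thus within the scatter. For compound 4 the estimate is 21000 nM with an expected range from 10000 nM to 42000 nM in this test.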

Compound 4, half-maximal cytotoxic concentration: 21500 nM
The estimate for compound 4 lay 1.0-fold (0.01 log units) below the measured number; low and high end bracket the measured number.
By their numbers in this assay, from the lowest: compounds 1, 4, 3 and 2 (each within the scatter of the next, the first and the last beyond it).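

In this assay, the step of a 1.1-fold lower number from compound 3 to compound 4 (0.03 log units; within the scatter) lies within the scatter, so at this place, para to a large group, chloro and fluoro cannot be told apart. Among the compounds shown here, this is the first direct look at a change on the 4-fluorophenyl ring, and swapping one halogen for the other gives no readable difference in cytotoxicity. On these data alone, whether this position matters at all remains open, since a very different group there, such as an amine or a carboxylic acid, would test it far harder. Nothing at hand explains why the two halogens match.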